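The compounds below may be only part of what the source reports. "The series", "measured", "known", "first", "only" and "open" are said of these compounds alone.

Measured compounds in the series:

Compound 1 `Nc1nc(N)c2c(-c3cc4ccccc4o3)cn([C@@H]3O[C@H](CO)[C@@H](O)[C@H]3O)c2n1` — in a functional assay on HL-60 cells (Homo sapiens) for antiproliferative activity, read by XTT assay, with a stated time of 72 h (on this read-out lower numbers stand for stronger inhibition and higher numbers for weaker inhibition), compound 1 reaches only the limit > 15000 nM.
Compound 2 `Cc1nc(N)c2c(-c3cc4ccccc4o3)cn([C@@H]3O[C@H](CO)[C@@H](O)[C@H]3O)c2n1` — in this assay compound 2 reaches only the limit > 20000 nM.
Compound 3 `Nc1nc2c(c(-c3ccsc3)cn2[C@@H]2O[C@H](CO)[C@@H](O)[C@H]2O)c(=O)[nH]1` — in this assay compound 3 reaches only the limit > 20000 nM.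

Among the compounds with values here, every value shown is a limit, so no compound can be placed above or below another. Within the data shown here, the only single-point comparison, a step that the two limits leave unreadable from compound 1 to compound 2, is unreadable because compound 1 sits at the limit of > 15000 nM in this assay, at which 1 of the 3 values shown sits, and compound 2 sits at the limit of > 20000 nM in this assay, at which 2 of the 3 values shown sit. Compound 2 therefore stands at a limit, alongside the two further values, which are limits as well.

Compound 4 `Cc1nc(N)c2c(I)cn([C@@H]3O[C@H](CO)[C@@H](O)[C@H]3O)c2n1` differs from compound 2 by iodo in place of 1-benzofuran-2-yl on an aromatic carbon. Among the measured compounds shown here, no measured step bears on this change; the one step measured concerns a different position and is itself unreadable. The shared core carrying the sugar gives only limits in all three measured cases, and nothing in the numbers points either way for the exchange at this position. The expected step of an at least 1.3-fold lower number from compound 2 to compound 4 (0.12 log units; that floor lies within the scatter) in this assay is accordingly none beyond the scatter. Compound 4 is estimated at 15000 nM, with a range from 3000 nM to 50000 nM, and most likely the result is again a limit rather than a number.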

Compound 4, half-maximal inhibitory concentration: 2050 nM
The estimate for compound 4 lay 7.3-fold (0.86 log units) above the measured number, outside the stated range (below it).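

Within the data shown here, the exchange at this aromatic carbon gives the first readable step in this assay: an at least 9.7-fold lower number from compound 2 to compound 4 (0.98 log units; beyond the scatter). The earlier compounds shown here gave only limits, so they could not show that the shared core with its sugar can reach a measurable number; with iodo at this carbon and methyl kept in place, it does, and the group at this position therefore bears strongly on the read-out. The size of the step is only a floor, because compound 2 stands at a limit and not at a number: the limit of > 20000 nM in this assay, at which 2 of the 4 values shown sit.

As far as these compounds go, it remains open whether the lower number belongs to iodo itself or simply to the departure of 1-benzofuran-2-yl, a question that a bromo, a chloro or a phenyl group at the same carbon would help to settle. It also remains open whether methyl matters once iodo is present, since the comparison of amino and methyl is available only with 1-benzofuran-2-yl in place, where it cannot be read, and an amino group alongside iodo does not appear among the compounds shown.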